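This account rests on a few compounds, and the source may have more. Where it says the series, first, only, none or still open, it means among the compounds named here.

Measured in a functional assay on HT-29 cells (Homo sapiens) for cytotoxicity, read by sulforhodamine B assay; on this read-out lower numbers stand for stronger inhibition of growth and higher numbers for weaker inhibition of growth:
- compound 1 `COC1=C(Br)[C@H](O)[C@@]2(C=C1Br)CC(C(=O)NCCCCNC(=O)C1=NO[C@]3(C=C(Br)C(=O)[C@@H](Br)[C@@H]3O)C1)=NO2`: 4100 nM
- compound 2 `O=C(NCCCCCNC(=O)C1=NO[C@]2(C=C(Br)C(=O)[C@H](Br)[C@@H]2O)C1)C1=NO[C@]2(C=C(Br)C(=O)[C@H](Br)[C@@H]2O)C1`: 1600 nM

Compound 1 holds the higher of the two numbers, and the gap down to compound 2 lies beyond the scatter. The next compound is compound 3 `COC1=C(Br)[C@H](O)[C@@]2(C=C1Br)CC(C(=O)NCCCCNC(=O)C1=NO[C@]3(C=C(Br)C(=O)[C@H](Br)[C@@H]3O)C1)=NO2`, and its change from compound 1 is this: the two compounds have the same atoms and bonds and differ only in configuration as drawn: 1 of 5 stereo elements differ; a stereocentre at a saturated ring carbon is drawn S in compound 1 and R in compound 3. Among the compounds with values here, no measured pair isolates such a change, so the expectation is loose: a small move toward a lower number, not beyond the scatter. The expected step runs a 1.4-fold lower number from compound 1 to compound 3 (0.14 log units; within the scatter). The estimate for compound 3 is 3000 nM, with an expected range from 1200 nM to 7000 nM.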

Compound 3, concentration for 50% growth inhibition: 3400 nM
For compound 3 the middle estimate is 1.1-fold (0.05 log units) below the measured one, and the stated range covers the measured number.
By their numbers in this assay, from the lowest: compound 2; then compounds 3 and 1 (each within the scatter of the next).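

In this assay, the change at this saturated ring carbon, drawn S in compound 1 and R in compound 3, gives a 1.2-fold lower number from compound 1 to compound 3 (0.08 log units; within the scatter). Within the data shown here, this is the first measured pair to isolate a configuration change, and at this stereocentre the read-out does not separate the two forms. The comparison is clean on structure alone: the fact that compounds 1 and 3 differ only in the configuration as drawn

Among these compounds, the remaining stereo elements stay open, since no pair isolates any of them. Also open, from the compounds shown here alone, is whether this stereocentre would stay as undifferentiated in a compound carrying an amine or a carboxylic acid.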